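A few compounds are considered here, and "the series" means these few. Any claim that something is new, unique, unknown or untested is made for them only; others in the source may bear on it.

Measured compounds in an ADME assay on microsomes from liver (Rattus norvegicus) for metabolic stability, read by LC-MS, using NADPH; a lower number here means that the compound disappears faster, a higher number that the compound lasts longer:
compound 1 `O=C(NCCCCN1CCN(c2cccc(Cl)c2)CC1)c1ccc(-c2ccsc2)cc1`; compound 1 gives 0.468 h.
compound 2 `COc1ccccc1N1CCN(CCCCNC(=O)c2ccc(-c3ccsc3)cc2)CC1`; compound 2 gives 0.04 h.
compound 3 `O=C(NCCCCN1CCN(c2ccccc2O)CC1)c1ccc(-c2ccsc2)cc1`; compound 3 gives 0.157 h.

On these numbers compound 3 stands second highest of the three, separated from compound 1 by a 3.0-fold lower number from compound 1 to compound 3 (0.47 log units; beyond the scatter) and from compound 2 by a 3.9-fold higher number from compound 2 to compound 3 (0.59 log units; beyond the scatter). Compound 4 `O=C(NCCCCN1CCN(c2cccc(O)c2)CC1)c1ccc(-c2ccsc2)cc1` differs from compound 3 in one place: 3-hydroxyphenyl in place of 2-hydroxyphenyl on an amine nitrogen in a ring. Within the data shown here, only a 3.0-fold lower number from compound 1 to compound 3 (0.47 log units; beyond the scatter) bears on this change, since it alters the group at the same position of the shared core, yet no measured pair moves a hydroxyl between ring positions. A modest step is therefore expected in this assay, its direction uncertain, a 1.3-fold higher number from compound 3 to compound 4 (0.11 log units; within the scatter). Compound 4 is estimated at 0.2 h, within 0.07 h to 0.6 h.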

Compound 4, half-life: 0.085 h
Beside the measured number, compound 4's estimate is 2.4-fold (0.37 log units) above it; low and high end bracket the measured number.
By their numbers in this assay, from the lowest: compound 2; then compounds 4 and 3 (each within the scatter of the next); then compound 1.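

In this assay, moving the hydroxyl gives 3-hydroxyphenyl in place of 2-hydroxyphenyl and a 1.8-fold lower number from compound 3 to compound 4 (0.27 log units; within the scatter), so at this position the place of the hydroxyl on the aromatic ring shows no change that can be told from the scatter. Hydroxy in place of chloro gives a 5.5-fold lower number from compound 1 to compound 4 (0.74 log units; beyond the scatter), while 3-hydroxyphenyl in place of 2-methoxyphenyl gives a 2.1-fold higher number from compound 2 to compound 4 (0.33 log units; beyond the scatter), which places compound 4 clearly apart from both. Nothing measured here speaks to the cause of these steps.

Going by these compounds, whether an amino group or a fluorine in place of the hydroxy on the 3-hydroxyphenyl ring would follow compound 4 or compound 1 remains open.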